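Ring-size change on the amine of compound 2

The compounds below may be only part of what the source reports. "The series", "measured", "known", "first", "only" and "open" are said of these compounds alone.

Of the compounds shown here, two of the shared core have been measured in a functional assay on MCF7 cells (Homo sapiens) for antiproliferative activity, read by MTT assay, with a stated time of 72 h; a higher number here means a weaker inhibitor, a lower number a stronger inhibitor. Compound 1 `COc1cc2ncnc(N3CCCc4ccccc43)c2cc1NC(=O)C=C(C)C` gives 6870 nM. For the measured compounds named here, compound 2 `COc1cc2ncnc(N3CCCc4ccccc43)c2cc1NC(=O)/C=C/CN1CCCC1` gives 3190 nM, the lowest of the two numbers; the only neighbour is compound 1, and the step of a 2.2-fold lower number from compound 1 to compound 2 (0.33 log units; beyond the scatter) is modest but beyond the scatter.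

Compound 3 `COc1cc2ncnc(N3CCCc4ccccc43)c2cc1NC(=O)/C=C/CN1CCCCC1` differs from compound 2 by piperidin-1-yl in place of pyrrolidin-1-yl on a saturated chain carbon bound to a double-bonded chain carbon. Going by the values given here, no measured step exchanges one ring amine for another; the one step in hand replaces a whole chain end, so it bears on this change only loosely and tells nothing about the size of the amine ring on its own. The difference to compound 3 is confined to one added ring carbon at the far end of the chain, so the expected step of a 1.1-fold lower number from compound 2 to compound 3 (0.03 log units; within the scatter) from compound 2 to compound 3 is none beyond the scatter, with no direction favoured.

Compound 3 is therefore estimated at 3000 nM in this assay, with a range from 1300 nM to 7000 nM.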

Compound 3, half-maximal inhibitory concentration: 3930 nM
Compound 3: middle estimate off by 1.3-fold (0.12 log units), on the low side, and the stated range covers the measured number.
By their numbers in this assay, from the lowest: compounds 2, 3 and 1 (each within the scatter of the next, the first and the last beyond it).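

In this assay, the step of a 1.2-fold higher number from compound 2 to compound 3 (0.09 log units; within the scatter) shows that piperidin-1-yl in place of pyrrolidin-1-yl on a saturated chain carbon bound to a double-bonded chain carbon does not separate the two compounds, so in this pair the five-membered and six-membered non-aromatic rings cannot be told apart at this position. The chain end also reads less firmly against 2-methylprop-1-en-1-yl than compound 2 alone suggested: the step of a 1.7-fold lower number from compound 1 to compound 3 (0.24 log units; within the scatter) lies within the scatter, whereas the step of a 2.2-fold lower number from compound 1 to compound 2 (0.33 log units; beyond the scatter) lies beyond it, so a separation from compound 1 is not shared by both ring amines. No evidence is at hand that would explain either reading.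

From the compounds shown here alone, it remains open whether an open-chain amine such as dimethylamino, or a ring with a second hetero atom such as morpholin-4-yl, on the same chain carbon would stay within the scatter of compound 2 and compound 3. Also open, going by these compounds, is whether a smaller ring, azetidin-1-yl, or a larger one, azepan-1-yl, would give any step beyond the scatter.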